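Succinimide to thienylsulfanyl: a lipophilicity step on the oxazolidinone

A few compounds are considered here, and "the series" means these few. Any claim that something is new, unique, unknown or untested is made for them only; others in the source may bear on it.

Three compounds share a core and differ only at the saturated chain carbon bound to a saturated ring carbon. In a physicochemical assay for lipophilicity, read by HPLC, measured as octanol-water partition (a lower number here means a more polar compound, a higher number a more lipophilic compound), compound 1 `CN1CCN(C[C@H]2CN(c3ccc(-n4cc(-c5ccccn5)cn4)c(F)c3)C(=O)O2)CC1` gives 2.2, compound 2 `O=C1O[C@@H](CN2CCC(O)CC2)CN1c1ccc(-n2cc(-c3ccccn3)cn2)c(F)c1` gives 1.63, and compound 3 `O=C1CCC(=O)N1C[C@H]1CN(c2ccc(-n3cc(-c4ccccn4)cn3)c(F)c2)C(=O)O1` gives 1.58. Compound 3 has the lowest of the three numbers; its gap to compound 2 lies within the scatter, while a number 0.62 log units lower from compound 1 to compound 3 (beyond the scatter) and a number 0.57 log units lower from compound 1 to compound 2 (beyond the scatter) are beyond it. Compound 4 `O=C1O[C@@H](CSc2cccs2)CN1c1ccc(-n2cc(-c3ccccn3)cn2)c(F)c1` is unmeasured and differs from compound 3 by (thiophen-2-yl)sulfanyl in place of 2,5-dioxopyrrolidin-1-yl on a saturated chain carbon bound to a saturated ring carbon. Among the measured compounds shown here, no measured step carries a sulfur-linked aromatic group, so the bearing steps give only a sense of scale. The expected step is a number 1.92 log units higher from compound 3 to compound 4 (beyond the scatter), upward. Compound 4 is therefore estimated at 3.5, between 2.9 and 4.1.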

Compound 4, partition coefficient: 4.29
Compound 4: middle estimate off by 0.79 log units, on the low side; measured number above the stated range.
By their numbers in this assay, from the lowest: compounds 3 and 2 (each within the scatter of the next); then compound 1; then compound 4.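

With (thiophen-2-yl)sulfanyl on the saturated chain carbon bound to a saturated ring carbon, this assay shows a number 2.71 log units higher from compound 3 to compound 4 (beyond the scatter) and a number 2.66 log units higher from compound 2 to compound 4 (beyond the scatter) and also a number 2.09 log units higher from compound 1 to compound 4 (beyond the scatter) at this position. Among the compounds shown here, these large steps far exceed the modest ones among the earlier compounds, and they place compound 4 alone at the top of the series. No available evidence bears on the cause of these steps.

As far as these compounds go, it remains open whether the sulfur link or the thiophene ring accounts for the size of the step, which a phenylsulfanyl or a (thiophen-2-yl)methyl group would help separate. Also open, from the compounds shown here alone, is how this assay would read a primary amine or a carboxylic acid at this place.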